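Phenethyl in place of phenyl on the shared core

A few compounds are considered here, and "the series" means these few. Any claim that something is new, unique, unknown or untested is made for them only; others in the source may bear on it.

Compound 1 `C=C(Br)C(=O)Nc1cccc(-c2cn3nc(-c4ccccc4)sc3n2)c1` is the stronger of the two measured compounds in a functional assay on L1210 cells (Mus musculus) for inhibition, read by cell counting, with a stated time of 2 days (on this read-out lower numbers stand for stronger inhibition and higher numbers for weaker inhibition), where compound 1 gives 600 nM. Going by the values given here, the only other measured compound, compound 2 `COc1ccc(-c2csc3nc(-c4cccc(N)c4)cn23)cc1`, has a different core, and in this assay compound 2 gives 19000 nM; these two values show a wide gap, beyond the scatter, but no single step connects them. Compound 3 `C=C(Br)C(=O)Nc1cccc(-c2cn3nc(CCc4ccccc4)sc3n2)c1` keeps everything of compound 1 except for one change: phenethyl in place of phenyl on an aromatic carbon. Among the compounds with values here, no step of this kind has been measured among the compounds at hand, so the size of the effect cannot be read from any pair. For a change of this sort, with the rest of compound 1 untouched, a small shift toward weaker inhibition, not clearly beyond the scatter, is what compound 3 is expected to show, a 1.5-fold higher number from compound 1 to compound 3 (0.18 log units; within the scatter). Compound 3 is therefore estimated at 900 nM, with a range from 250 nM to 3500 nM.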

Compound 3, half-maximal inhibitory concentration: 2200 nM
Estimate against measurement, compound 3: 2.4-fold (0.39 log units) below; measured number inside the range.
By their numbers in this assay, from the lowest: compound 1; then compound 3; then compound 2.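

In this assay this position proves sensitive to the change: phenethyl in place of phenyl gives a 3.7-fold higher number from compound 1 to compound 3 (0.56 log units; beyond the scatter) and so provides the first measured size for a step here. Phenyl and phenethyl each hold one six-membered aromatic ring of carbon only, so the step separates two groups that differ in the chain joining that ring to the aromatic carbon, and inhibition weakens without being lost. No measurement at hand accounts for this step.

Going by these compounds, whether a benzyl group would fall between compound 1 and compound 3, or a longer phenylpropyl chain would weaken inhibition further, remains open. Also open, on these data alone, is how an amine or a carboxylic acid on the phenethyl chain would read in this assay at this position.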